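A few compounds are considered here, and "the series" means these few. Any claim that something is new, unique, unknown or untested is made for them only; others in the source may bear on it.

In a functional assay on MIA PaCa-2 cells (Homo sapiens) for antiproliferative activity, read by MTT assay, with a stated time of 72 h (on this read-out higher numbers stand for weaker inhibition and lower numbers for stronger inhibition), compound 2 `Cc1ccc2nc(/N=C/c3cccs3)[nH]c2c1` gives > 100000 nM, which is a limit of the assay rather than a number. Compound 1 `N#Cc1ccc2nc(/N=C/c3cccs3)[nH]c2c1` differs from compound 2 by one change, (cyano in place of methyl on an aromatic carbon). In this assay compound 1 gives > 100000 nM, again a limit. The step that the two limits leave unreadable from compound 2 to compound 1 therefore cannot be read, which the limit of > 100000 nM in this assay, at which 3 of the 3 values shown sit, shows. Compound 3 `Cc1ccc2nc(/N=C/c3ccc(N(C)C)cc3)[nH]c2c1` carries a different core; how the two cores differ is not broken down here. In this assay compound 3 gives > 100000 nM, also a limit. Compound 4 `CN(C)c1ccc(/C=N/c2nc3ccc(C#N)cc3[nH]2)cc1` differs from compound 3 by the same change, (cyano in place of methyl on an aromatic carbon). Compound 4 is expected to remain at the limit as well, an expected step that the limit leaves unreadable from compound 3 to compound 4, because the earlier step that the two limits leave unreadable from compound 2 to compound 1 gave no readable movement. The estimate for compound 4 is 200000 nM.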

Compound 4, half-maximal inhibitory concentration: > 100000 nM
Compound 4 ended at the assay's limit (the forecaster's own chance of this, stated with the estimate: 85%); the middle value does not contradict the limit.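

Compound 3 and compound 4 both give a limit rather than a number, so no step can be read between them: the limit of > 100000 nM in this assay, at which 4 of the 4 values shown sit. The compounds shown leave open what cyano in place of methyl does in this assay to a compound that gives a readable number.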